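Hydrazone aryl replacement: hydroxyl and fluorine returning

The source may report more compounds than this note shows. Statements on the series, on what has been measured and on what is new or still open speak of the compounds shown alone.

For the measured compounds named here, compound 3 `COc1ccccc1/C=N\NC(=O)c1oc2cccc(O)c2c1C` gives 32700 nM in a functional assay on PC-3 cells (Homo sapiens) for inhibition (on this read-out lower numbers stand for stronger inhibition and higher numbers for weaker inhibition), the highest number of the three measured so far. Compound 1 `Cc1c(C(=O)N/N=C\c2c(O)cccc2F)oc2cccc(O)c12` gives 8050 nM and compound 2 `Cc1c(C(=O)N/N=C\c2c(O)cccc2Cl)oc2cccc(O)c12` gives 18700 nM. Compound 4 `Cc1c(C(=O)N/N=C\c2cc(F)ccc2O)oc2cccc(O)c12` differs from compound 3 as follows: 5-fluoro-2-hydroxyphenyl in place of 2-methoxyphenyl on a carbon with a double bond to nitrogen. Going by the values given here, two measured steps bear on this change, both running in the opposite direction, from a hydroxyl-and-halogen-bearing phenyl to the methoxyphenyl: a 4.1-fold higher number from compound 1 to compound 3 (0.61 log units; beyond the scatter) and a 1.7-fold higher number from compound 2 to compound 3 (0.24 log units; within the scatter). The hydroxyl-bearing phenyls thus gave lower numbers than the methoxyphenyl, modestly with fluorine and within the scatter with chlorine. Compound 4 carries a hydroxyl and a fluorine on the phenyl, though on different ring positions than compound 1, so the gain is expected to be real but smaller and uncertain. Compound 4 is therefore expected to show a 2.7-fold lower number from compound 3 to compound 4 (0.44 log units; beyond the scatter) in this assay. The estimate for compound 4 is 12000 nM, with a range from 4000 nM to 35000 nM.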

Compound 4, half-maximal inhibitory concentration: 3170 nM
Compound 4: middle estimate off by 3.8-fold (0.58 log units), on the high side; measured number outside the range, below it.
By their numbers in this assay, from the lowest: compound 4; then compound 1; then compounds 2 and 3 (each within the scatter of the next).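

In this assay, this is the largest step yet seen at this position: a 10-fold lower number from compound 3 to compound 4 (1.01 log units; beyond the scatter) exceeds anything the earlier replacements of 2-methoxyphenyl suggested. A hydroxyl and a halogen on the phenyl do not by themselves set the number, since 5-fluoro-2-hydroxyphenyl also separates from both earlier hydroxyl-bearing phenyls, with a 2.5-fold lower number from compound 1 to compound 4 (0.40 log units; beyond the scatter) and a 5.9-fold lower number from compound 2 to compound 4 (0.77 log units; beyond the scatter), which makes compound 4 the lowest of the four, and compound 1 and compound 4 carry the same kinds of substituent arranged differently. Nothing shown here accounts for this ordering.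

On these data alone, how much of the step from compound 3 belongs to the hydroxyl and how much to the fluorine remains open. So does the outcome of an amine or a carboxylic acid in place of that hydroxyl on the 5-fluorophenyl.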